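Moving the Bromine Around a Ring: What to Expect

This account rests on a few compounds, and the source may have more. Where it says the series, first, only, none or still open, it means among the compounds named here.

Of the compounds shown here, three have been tested in a functional assay on Caco-2 cells (Homo sapiens) for inhibition, read by MTT assay, with a stated time of 48 h; on this read-out lower numbers stand for stronger inhibition and higher numbers for weaker inhibition. Compound 1 `COc1cc(/C=N/Nc2nc(-c3ccc(Br)cc3)cs2)cc(Br)c1OC` gives 36200 nM, compound 2 `COc1cc(/C=N/Nc2nc(-c3cccc(Br)c3)cs2)cc(Br)c1OC` gives 43400 nM, and compound 3 `Fc1ccc(/C=N/Nc2nc(-c3cccc(Br)c3)cs2)cc1F` gives 17500 nM, the lowest of the three. Compounds 1 and 2 share a core and differ only in 4-bromophenyl in place of 3-bromophenyl on an aromatic carbon; this change produced a 1.2-fold lower number from compound 2 to compound 1 (0.08 log units; within the scatter). The difference between the cores of compound 2 and compound 3 is not broken down here. Compound 4 `Fc1ccc(/C=N/Nc2nc(-c3ccc(Br)cc3)cs2)cc1F` has not yet been measured; it differs from compound 3 by 4-bromophenyl in place of 3-bromophenyl on an aromatic carbon, the same change as between compound 2 and compound 1, at the same place. Because the earlier step was a 1.2-fold lower number from compound 2 to compound 1 (0.08 log units; within the scatter), a similarly small step is expected here, a 1.2-fold lower number from compound 3 to compound 4 (0.07 log units; within the scatter). Compound 4 is therefore estimated at 15000 nM, most likely between 6000 nM and 40000 nM.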

Compound 4, half-maximal inhibitory concentration: 43900 nM
The estimate for compound 4 lay 2.9-fold (0.47 log units) below the measured number; the measured number lies above the stated range.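

Putting 4-bromophenyl in place of 3-bromophenyl gave, in this assay, a 2.5-fold higher number from compound 3 to compound 4 (0.40 log units; beyond the scatter). The outcome of this change therefore depends on the core that carries it, so a step seen on one core is not a safe guide to the step on another: the same change on two cores in this assay, a 1.2-fold lower number (0.08 log units; within the scatter) from compound 2 to compound 1 and a 2.5-fold higher number (0.40 log units; beyond the scatter) from compound 3 to compound 4, 3.0-fold (0.48 log units) apart, beyond the scatter of two such steps

This does not show which part of the two cores is responsible, and two pairs are too few to give a rule for the series. The compounds shown leave open how the same change behaves on a core bearing an amine or a carboxylic acid in place of the groups seen here. Also open, on these data alone, is whether a chlorophenyl group would follow either of these two results.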